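From Sulfonamide to Thioester on a Shared Core

The compounds below may be only part of what the source reports. "The series", "measured", "known", "first", "only" and "open" are said of these compounds alone.

Compound 1 `COc1ccc(-c2c(C)nc3c(N4CC[C@@H](NS(=O)(=O)c5ccccc5)C4)cc(C)nn23)cc1OC` was tested in an ADME assay on microsomes from liver (Homo sapiens) for metabolic stability, read by LC-MS, with NADPH named in the record, with a stated time of 60 min, tested at 1 uM, in the absence of a further agent; a lower number here means that less of the compound is left, a higher number that more of the compound is left. In this assay compound 1 gives > 95%, which is a limit of the assay rather than a number. Compound 2 `COc1ccc(-c2c(C)nc3c(N4CC[C@@H](NS(=O)(=O)c5ccc(C(C)=O)cc5)C4)cc(C)nn23)cc1OC` carries acetyl in place of hydrogen on an aromatic carbon. In this assay compound 2 gives > 95%, again a limit of the assay. The step that the two limits leave unreadable from compound 1 to compound 2 therefore cannot be read, as the limit of > 95% in this assay, at which 2 of the 2 values shown sit, shows; compound 1 thus stands only at a limit, with nothing to set it apart from compound 2.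

Compound 3 `COc1ccc(-c2c(C)nc3c(N4CC[C@@H](SC(C)=O)C4)cc(C)nn23)cc1OC` differs from compound 1 in another way: acetylsulfanyl in place of (phenylsulfonyl)amino on a saturated ring carbon. Among the measured compounds shown here, no measured step covers such an exchange, and the single measured step that the two limits leave unreadable from compound 1 to compound 2 bears on it only by showing that an acetyl added on the aromatic ring of the leaving group did not move the value off the limit. For compound 3 a drop in this assay is expected, by a step of a number at least 35 percentage points lower from compound 1 to compound 3 (beyond the scatter). Compound 3 is therefore estimated at 60%, within a range from 20% to 95%, with a fair chance that the assay again reports only a limit.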

Compound 3, percent of the compound remaining: > 95%
Compound 3 was reported as a limit (the forecaster's own chance of this, stated with the estimate: 30%); at least 35 percentage points between middle value and limit.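

In this assay compound 3 gives > 95%, which is a limit of the assay and not a number. No step from compound 1 to compound 3 or compound 2 can therefore be read: the limit of > 95% in this assay, at which 3 of the 3 values shown sit.

The compounds shown leave open how compound 1, compound 2 and compound 3 truly compare in this assay, and which change to the shared core would leave less compound remaining.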